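A few compounds are considered here, and "the series" means these few. Any claim that something is new, unique, unknown or untested is made for them only; others in the source may bear on it.

Compound 1 `COc1cc[nH]c1/C=C1\C(=O)Nc2ccc([N+](=O)[O-])c(N[C@H]3CC[C@H](O)C3)c21` carries a (3-hydroxycyclopentyl)amino group on the core shared by the series. In a functional assay on MDA-MB-435 cells (Homo sapiens) for antiproliferative activity, read by MTT assay, with a stated time of 5 days (a lower number here means a stronger inhibitor, a higher number a weaker inhibitor), compound 1 gives 1000 nM, the highest of the two numbers recorded so far. For the measured compounds named here, its nearest neighbour is compound 2 `COc1cc[nH]c1/C=C1\C(=O)Nc2ccc([N+](=O)[O-])c(N[C@H]3CC[C@H](N)C3)c21`, which in this assay gives 61 nM; the single change of amino in place of hydroxy on a saturated ring carbon produced a 16-fold lower number from compound 1 to compound 2 (1.21 log units; beyond the scatter).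

Compound 3 `COc1cc[nH]c1/C=C1\C(=O)Nc2ccc([N+](=O)[O-])c(N3CC[C@@H](N)C3)c21` is not yet measured. It differs from compound 1 in one place: 3-aminopyrrolidin-1-yl in place of (3-hydroxycyclopentyl)amino on an aromatic carbon. Going by the values given here, the pyrrolidine of compound 3 keeps a primary amino group on its saturated ring, as compound 2 does, so the step from compound 1 to compound 2 is the only measured comparison that bears on it. That step was large and toward a lower number. Among the compounds with values here, the ring of compound 3, however, is attached through its own nitrogen rather than through an exocyclic amino, and no measured pair speaks to that part of the change, so the expectation is held somewhat short of the full gain seen in compound 2. For compound 3 the expected step is a 6.7-fold lower number from compound 1 to compound 3 (0.82 log units; beyond the scatter), giving an estimate of 150 nM with a range from 40 nM to 600 nM.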

Compound 3, half-maximal inhibitory concentration: < 10 nM
Compound 3: a limit, no number; the forecaster's own chance of this, stated with the estimate: 2%; at least 15-fold (1.17 log units) between middle value and limit.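

For the compounds shown here, at this position, on an aromatic carbon ortho to a nitro group, the earlier compounds showed only that an amino group outperforms a hydroxy group on the saturated ring; the new result shows that the way the ring is attached also matters. With the primary amino group kept, 3-aminopyrrolidin-1-yl in place of (3-aminocyclopentyl)amino gives an at least 6.1-fold lower number from compound 2 to compound 3 (0.78 log units; beyond the scatter), so the gain does not stop at the level reached by the amino-for-hydroxy change. The full replacement gives an at least 100-fold lower number from compound 1 to compound 3 (2.00 log units; beyond the scatter), and in this assay compound 3 stands as a limit of the assay and not as a number: the limit of < 10 nM in this assay, at which 1 of the 3 values shown sits.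

Still open, going by these compounds, is whether the gain comes from the ring nitrogen attachment alone or needs the primary amino group as well, a question that 3-hydroxypyrrolidin-1-yl, 3-(dimethylamino)pyrrolidin-1-yl or piperazin-1-yl at the same aromatic carbon would address. Also open, on these data alone, are the mirror-image form of 3-aminopyrrolidin-1-yl and the true size of both new steps, each of which is bounded on one side only.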